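Aryl replacement on the hydrazone carbon in a urea series

A few compounds are considered here, and "the series" means these few. Any claim that something is new, unique, unknown or untested is made for them only; others in the source may bear on it.

For the measured compounds named here, compound 2 `CN(C)CCn1cnnc1-c1cc(Oc2ccc(NC(=O)N/N=C/c3c(O)ccc4ccccc34)cc2F)ccn1` gives the lowest of the two numbers so far in an ADME assay on WI-38 cells (Homo sapiens) for cytotoxicity, read by MTT assay, with a stated time of 72 h; a lower number here means a stronger inhibitor, a higher number a weaker inhibitor: compound 2 gives 3250 nM, while compound 1 `COc1ccc(/C=N/NC(=O)Nc2ccc(Oc3ccnc(-c4nncn4CCN(C)C)c3)c(F)c2)c(OC)c1` gives 6630 nM. Going by the values given here, the one measured step on this position, a 2.0-fold lower number from compound 1 to compound 2 (0.31 log units; beyond the scatter), is the only one that bears on the change now made. Compound 3 `CN(C)CCn1cnnc1-c1cc(Oc2ccc(NC(=O)N/N=C/c3ccc(Cl)cc3)cc2F)ccn1` differs from compound 2 by 4-chlorophenyl in place of 2-hydroxynaphthalen-1-yl on a carbon with a double bond to nitrogen. Among the compounds with values here, that step touches the same carbon as the step from compound 1 to compound 2, but the group entering is a third aryl group, and no measured pair shows what the 4-chlorophenyl group does here. With one modest step as the whole basis, no step beyond the scatter is expected in this assay from compound 2 to compound 3; the most that can be read from compound 1 giving 6630 nM is a drift back toward that number. Compound 3 is therefore estimated at 5000 nM, with a range of 2000 nM to 12000 nM, which means an expected step of a 1.5-fold higher number from compound 2 to compound 3 (0.19 log units; within the scatter).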

Compound 3, half-maximal inhibitory concentration: 1870 nM
Beside the measured number, compound 3's estimate is 2.7-fold (0.43 log units) above it, and the stated range ends above it.
By their numbers in this assay, from the lowest: compounds 3 and 2 (each within the scatter of the next); then compound 1.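

At this carbon, a 1.7-fold lower number from compound 2 to compound 3 (0.24 log units; within the scatter), so in this assay a single ring carrying chlorine cannot be told apart from the two-ring 2-hydroxynaphthalen-1-yl group, even though the hydroxyl and four heavy atoms are lost. Against 2,4-dimethoxyphenyl the picture is clearer: the number runs a 3.5-fold lower number from compound 1 to compound 3 (0.55 log units; beyond the scatter), beyond the scatter like the earlier step, which makes compound 1 the highest of the three and sets 2,4-dimethoxyphenyl apart from both other aryl groups. Nothing on hand accounts for these differences.

As far as these compounds go, what a plain phenyl ring or a 4-fluorophenyl ring would give at this carbon remains open, and with it whether the chlorine contributes anything. Also open, from the compounds shown here alone, is whether a saturated ring such as cyclohexyl would keep the number in this range.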